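The source may hold more compounds than are shown below. What is called first, only, known or untested is meant among the compounds shown, and "the series" means these compounds.

Measured so far in a functional assay on HCT-116 cells (Homo sapiens) for cytotoxicity, read by MTT assay, with a stated time of 2 days; on this read-out lower numbers stand for stronger inhibition and higher numbers for weaker inhibition:

- compound 1, `CCCCCNc1nc(NCc2ccco2)c2cc(F)ccc2n1`, gives 4100 nM
- compound 2, `Clc1cccc(N2CCN(CCCCNc3nc(NCc4ccco4)c4ccccc4n3)CC2)c1Cl`, gives 3200 nM
- compound 3, `CCN(CC)CCNc1nc(NCc2ccco2)c2ccccc2n1`, gives 25900 nM

Of the three numbers, compound 1 stands second highest. Its nearest neighbour is compound 2, whose value lies within the usual scatter of compound 1, so no order between the two can be read. Compound 3 lies furthest from compound 1, with a clearly higher number, a gap beyond the scatter; as the side chain on the shared core is different in kind in all three, the pairs tell nothing about one isolated change.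

Compound 4, `COc1ccc(Nc2nc(NCc3ccco3)c3cc(F)ccc3n2)cc1`, is not yet measured. It differs from compound 1 in one place:

4-methoxyphenyl in place of pentyl on a nitrogen on an aromatic ring

The change sits on a nitrogen on an aromatic ring whose other neighbour is aromatic carbon; read one bond further out, pentylamino becomes (4-methoxyphenyl)amino. For the measured compounds named here, no measured pair shows this exchange, so the only anchor is compound 1 at 4100 nM. The step of a 1.3-fold lower number from compound 1 to compound 4 (0.11 log units; within the scatter) is expected to be small, within the scatter or only a little beyond it, with no firm direction. Compound 4 is therefore estimated at 3200 nM in this assay, with a range from 800 nM to 13000 nM.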

Compound 4, half-maximal inhibitory concentration: 6150 nM
Estimate against measurement, compound 4: 1.9-fold (0.28 log units) below; measured number inside the range.
By their numbers in this assay, from the lowest: compounds 2, 1 and 4 (each within the scatter of the next); then compound 3.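

In this assay, for the compounds shown here, the exchange of pentyl for 4-methoxyphenyl on a nitrogen on an aromatic ring gives a 1.5-fold higher number from compound 1 to compound 4 (0.18 log units; within the scatter), the first step that can be read as one isolated change. The earlier compounds shown here differed in kind at their side chains and could not show this. Here an open chain gives way to a six-membered aromatic ring of carbon only, carrying a hydrogen-bond acceptor, and the read-out does not separate compound 1 from compound 4, so at this position, in this one pair, such an exchange leaves the number within the scatter. Nothing in the data at hand bears on why the two compounds are not separated.

Going by these compounds alone, the single pair cannot tell whether the ring or the methoxy group matters more, and a plain phenyl would be needed to divide the two. Within the data shown here, also open is whether a carboxylic acid or a longer chain at this position would move the number beyond the scatter, and what the fluorine on the shared core contributes, as no pair isolates it.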